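This account rests on a few compounds, and the source may have more. Where it says the series, first, only, none or still open, it means among the compounds named here.

In a functional assay on CCRF-CEM cells (Homo sapiens) for cytotoxicity, read by cell counting, with a stated time of 3 days (a higher number here means a weaker inhibitor, a lower number a stronger inhibitor), compound 2 `C=C(Br)C(=O)Nc1cccc(/C=C2\SC(=O)N(Cc3ccc(C(F)(F)F)cc3)C2=O)c1` gives 920 nM, the lowest of the two numbers recorded here, and the nearest number is that of compound 1 `Nc1cccc(/C=C2\SC(=O)N(Cc3cccc(Cl)c3)C2=O)c1` at 195000 nM. Compound 3 `Cc1ccc(CN2C(=O)S/C(=C\c3cccc(N)c3)C2=O)cc1` reaches only the limit of this assay, at > 250000 nM. Going by the values given here, the one single-point step at the aryl group on the saturated chain carbon bound to the amide-type nitrogen in the ring, an at least 1.2-fold higher number from compound 1 to compound 3 (0.10 log units; that floor lies within the scatter), has a floor that lies within the scatter, and the line the limit of > 250000 nM in this assay, at which 1 of the 3 values shown sits, shows that this floor is set by the limit. Compound 4 `C=C(Br)C(=O)Nc1cccc(/C=C2\SC(=O)N(Cc3cccc(Cl)c3)C2=O)c1` arises from compound 2 by the change (3-chlorophenyl in place of 4-(trifluoromethyl)phenyl on a saturated chain carbon bound to an amide-type nitrogen in a ring). Among the compounds with values here, compound 2 and compound 1 differ in two places at once, so their gap cannot be assigned to the aryl group alone; the only single-point evidence on this aryl position stays within the scatter. Compound 4 is therefore expected to sit close to compound 2 in this assay, with the step of a 1.6-fold higher number from compound 2 to compound 4 (0.21 log units; within the scatter) expected to remain within the scatter. The estimate for compound 4 is 1500 nM, between 400 nM and 6000 nM.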

Compound 4, half-maximal inhibitory concentration: 1400 nM
The estimate for compound 4 lay 1.1-fold (0.03 log units) above the measured number, and the stated range covers the measured number.
By their numbers in this assay, from the lowest: compounds 2 and 4 (each within the scatter of the next); then compound 1. At a limit, above all of these: compound 3.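

In this assay, the aryl group on a saturated chain carbon bound to an amide-type nitrogen in a ring now has a step read between two numbers, not a floor set by a limit: a 1.5-fold higher number from compound 2 to compound 4 (0.18 log units; within the scatter). Thus 3-chlorophenyl in place of 4-(trifluoromethyl)phenyl leaves the number within the scatter. The large change lies at the other place, where (1-bromoethenyl)carbonyl stands in place of hydrogen on a nitrogen on an aromatic ring, with a 140-fold lower number from compound 1 to compound 4 (2.14 log units; beyond the scatter), and no measurement shown gives a cause for either step.

The compounds shown leave open whether the bromine of that group matters, a question that a plain acetyl on the same nitrogen would begin to address. Going by these compounds, how the number responds to an amine or a carboxylic acid on the phenyl ring also stays open.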